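Cyclohexyl in Place of an Aromatic Ring on the Amide

The source may hold more compounds than are shown below. What is called first, only, known or untested is meant among the compounds shown, and "the series" means these compounds.

Compound 1 `Cn1c(-c2ccccc2)cnc1NC(=O)c1ccccc1`, compound 2 `Cc1ccccc1C(=O)Nc1ncc(-c2ccccc2)n1C` and compound 3 `Cc1ccc(C(=O)Nc2ncc(-c3ccccc3)n2C)cc1` share one core and differ only in the group on the carbonyl carbon. In a toxicity assay on THP-1 cells (Homo sapiens) for inhibition (a lower number here means that less compound is tolerated, a higher number that more compound is tolerated), compound 1 reaches only the limit of the test, > 100000 nM. Compound 2 also stops at a limit, > 100000 nM. Compound 3 stops at a limit too, > 50000 nM. All three values are limits, so the steps a step that the two limits leave unreadable from compound 1 to compound 2, a step that the two limits leave unreadable from compound 1 to compound 3 and a step that the two limits leave unreadable from compound 2 to compound 3 have no readable size; what is known is summed up by the limit of > 100000 nM in this assay, at which 2 of the 3 values shown sit, and (the limit of > 50000 nM in this assay, at which 1 of the 3 values shown sits). Compound 3 therefore stands at a limit, not at a number, and cannot be ranked against compound 1 or compound 2.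

Compound 4 `Cn1c(-c2ccccc2)cnc1NC(=O)C1CCCCC1` alters compound 3 by cyclohexyl in place of 4-methylphenyl on a carbonyl carbon. Among the measured compounds shown here, no measured step involves a non-aromatic ring in this position, and the measured steps themselves carry no readable size, so the change gives no direction to expect. The step that the limit leaves unreadable from compound 3 to compound 4 is estimated to show nothing beyond the scatter, with compound 4 most likely again at a limit. In this assay compound 4 is expected near 100000 nM, within 30000 nM to 300000 nM.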

Compound 4, half-maximal cytotoxic concentration: > 100000 nM
Compound 4: no number, only a limit; the forecaster's own chance of this, stated with the estimate: 80%; the middle value sits exactly at the limit.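

In this assay compound 4 gives only a limit, > 100000 nM, so its steps from compound 1, compound 2 and compound 3 cannot be read. The compounds shown leave open at what concentration any of them becomes toxic, and whether the group on the carbonyl carbon matters.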